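Lengthening a polyamine tail on a chalcone-type scaffold

This account rests on a few compounds, and the source may have more. Where it says the series, first, only, none or still open, it means among the compounds named here.

Compound 1 `COc1cc(C(=O)/C=C/c2ccc(OCCCC(=O)NCCCNCCCCN)cc2)cc(OC)c1OC`: > 100000 nM, a limit of the assay.
Compound 2 `COc1cc(C(=O)/C=C/c2ccc(OCCCC(=O)NCCCCN(CCCN)CCCCN)cc2)cc(OC)c1OC`: 87200 nM.
Compound 3 `COc1cc(C(=O)/C=C/c2ccc(OCCCC(=O)NCCCNCCCCNCCN)cc2)cc(OC)c1OC`: 98000 nM.

In a functional assay on HT-29 cells (Homo sapiens) for antiproliferative activity, read by MTT assay, with a stated time of 48 h (a higher number here means a weaker inhibitor, a lower number a stronger inhibitor), compound 2 gives the lowest of the two numbers recorded, with compound 3 as its nearest neighbour at a 1.1-fold higher number from compound 2 to compound 3 (0.05 log units; within the scatter). For compound 1 only a limit is known, (the limit of > 100000 nM in this assay, at which 1 of the 3 values shown sits), so no number can be compared. Compound 4 `COc1cc(C(=O)/C=C/c2ccc(OCCCC(=O)NCCCCN(CCCN)CCCCNCCCN)cc2)cc(OC)c1OC` differs from compound 2 by 3-aminopropyl in place of hydrogen on an amine nitrogen. For the measured compounds named here, two measured steps bear on this. The step of an at least 1.0-fold lower number from compound 1 to compound 3 (0.00 log units; that floor lies within the scatter) added an aminoalkyl piece to an amine nitrogen and stayed within the scatter. The step of an at least 1.1-fold lower number from compound 1 to compound 2 (0.05 log units; that floor lies within the scatter) extended the chain with a further basic nitrogen and also stayed within the scatter. Neither shows a movement beyond the scatter for growth of the polyamine tail, so compound 4 is expected to behave like compound 2 in this assay, a step of a 1.1-fold lower number from compound 2 to compound 4 (0.04 log units; within the scatter) being anticipated. Compound 4 is therefore estimated at 80000 nM, within 40000 nM to 160000 nM.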

Compound 4, half-maximal inhibitory concentration: 91700 nM
The estimate for compound 4 lay 1.1-fold (0.06 log units) below the measured number, and the stated range covers the measured number.
By their numbers in this assay, from the lowest: compounds 2, 4 and 3 (each within the scatter of the next). At a limit, above all of these: compound 1.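

In this assay 3-aminopropyl in place of hydrogen on an amine nitrogen gives a 1.1-fold higher number from compound 2 to compound 4 (0.02 log units; within the scatter) and so stays within the scatter. For the compounds shown here, this is the first step of tail growth in which a number stands at both ends, since the earlier steps from compound 1 start from a limit of the assay: the limit of > 100000 nM in this assay, at which 1 of the 4 values shown sits. Among the compounds with numbers, then, this added 3-aminopropyl group on the amine nitrogen of compound 2 leaves the reading unmoved beyond the scatter.

The compounds shown leave open whether a carboxylic acid or a hydroxyl in place of the terminal amine of the 3-aminopropyl group, or a longer chain on this nitrogen, would move the number. As far as these compounds go, whether any tail on the shared core can reach a number beyond the scatter of these values also stays open.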